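The compounds below may be only part of what the source reports. "The series", "measured", "known", "first", "only" and "open" are said of these compounds alone.

Measured so far in a functional assay on PANC-1 cells (Homo sapiens) for inhibition, read by MTT assay, with a stated time of 24 h; on this read-out lower numbers stand for stronger inhibition and higher numbers for weaker inhibition
- compound 1 (`CC1(C)[C@H]2CC[C@]1(C)N(Cc1cn(-c3ccccc3C#N)nn1)C(=O)C2`) gives 240 nM
- compound 2 (`CC1(C)[C@H]2CC[C@]1(C)N(Cc1cn(-c3ccccc3)nn1)C(=O)C2`) gives 160 nM

Compound 2 (160 nM) is not separated from compound 1 beyond the scatter. Compound 3 (`CC1(C)[C@H]2CC[C@]1(C)N(Cc1cn(-c3ccc(Br)cc3)nn1)C(=O)C2`) takes phenyl to 4-bromophenyl, with bromo in place of hydrogen on an aromatic carbon, para to a large group (bromo in place of hydrogen on an aromatic carbon). Going by the values given here, the only measured step on this aromatic ring (a 1.5-fold lower number from compound 1 to compound 2 (0.18 log units; within the scatter)) involves a different group and stays within the scatter, so it offers weak guidance. No shift beyond the scatter is therefore expected (a 1.1-fold lower number from compound 2 to compound 3 (0.03 log units; within the scatter)) in this read-out (this assay). For compound 3 the estimated value is 150 nM, with an expected range of 60 nM to 380 nM.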

Compound 3, half-maximal inhibitory concentration: 200 nM
For compound 3 the middle estimate is 1.3-fold (0.12 log units) below the measured one; the range from low to high includes it.
By their numbers in this assay, from the lowest: compounds 2, 3 and 1 (each within the scatter of the next).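

In this assay, the step with bromo on an aromatic carbon, para to a large group, is a 1.3-fold higher number from compound 2 to compound 3 (0.10 log units; within the scatter), so this place accepts a bromine atom with no shift beyond the scatter. Exchanging 2-cyanophenyl for 4-bromophenyl gives a 1.2-fold lower number from compound 1 to compound 3 (0.08 log units; within the scatter), so the three aryl groups shown cannot be told apart in this read-out. No supporting data bear on why these numbers stay so close.

From the compounds shown here alone, whether an amine or a carboxylic acid at this place would move the number beyond the scatter remains open. So does the effect of any change to the shared core.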